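The source may hold more compounds than are shown below. What is called first, only, known or untested is meant among the compounds shown, and "the series" means these compounds.

Compound 2 `Cc1ccc(N2CCn3c2n[nH]c(=O)c3=O)cc1` and compound 1 `O=c1[nH]nc2n(c1=O)CCN2c1ccccc1` share a core and differ only by hydrogen in place of methyl on an aromatic carbon. In an ADME assay on Vero cells (Chlorocebus sabaeus) for cytotoxicity, with a stated time of 72 h, tested at 10 ug/mL (a lower number here means a weaker effect, a higher number a stronger effect of the compound at the concentration tested), compound 2 gives 0%, while compound 1 gives 7%; the step between them is a number 7 percentage points higher from compound 2 to compound 1 (within the scatter). Compound 3 `Cc1ccc(N2CCn3c2n[nH]c(=O)c3=N)cc1` carries the same methyl group on a different core; the difference between the two cores is not broken down here. In this assay compound 3 gives 0%, level with compound 2 at the digits reported and within the scatter of compound 1. Compound 4 `N=c1c(=O)[nH]nc2n1CCN2c1ccccc1` arises from compound 3 by the same change, (hydrogen in place of methyl on an aromatic carbon), at the same place. Because the step of a number 7 percentage points higher from compound 2 to compound 1 (within the scatter) lies within the scatter, a similarly small step is expected here. For compound 4 the expected step is a number 4 percentage points higher from compound 3 to compound 4 (within the scatter). Compound 4 is thus estimated to give 4% in this assay, between 0% and 14%.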

Compound 4, a percentage reported as inhibition, at one concentration (the size of the read-out at that concentration, not a potency): 26%
Compound 4: middle estimate off by 22 percentage points, on the low side; measured number outside the range, above it.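

In this assay, hydrogen in place of methyl on an aromatic carbon gives a number 26 percentage points higher from compound 3 to compound 4 (beyond the scatter). The same change therefore does not carry over at one size between these two cores: the same change on two cores in this assay, a number 7 percentage points higher (within the scatter) from compound 2 to compound 1 and a number 26 percentage points higher (beyond the scatter) from compound 3 to compound 4, 19 percentage points apart, beyond the scatter of two such steps

This shows that the size of the step depends on the core in these two pairs, but it does not show which feature of the core is responsible or how the step would run on any further core.

The compounds shown carry only hydrogen or methyl at this place on the aromatic ring. From the compounds shown here alone, how a chlorine atom, a methoxy group or an amine there would behave on either core remains open.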